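The source may report more compounds than this note shows. Statements on the series, on what has been measured and on what is new or still open speak of the compounds shown alone.

Measured so far in a functional assay on HeLa cells (Homo sapiens) for cytotoxicity; on this read-out lower numbers stand for higher toxicity in this test and higher numbers for lower toxicity in this test:
Compound 1 `COCCOC(=O)C(O)Cn1cnc2c(N)ncnc21` gives > 400 ug/mL, a limit of the test rather than a number.
Compound 2 `CC(C)COC(=O)C(O)Cn1cnc2c(N)ncnc21` gives > 400 ug/mL, also a limit.
Compound 3 `CC(C)CCOC(=O)C(O)Cn1cnc2c(N)ncnc21` gives 400 ug/mL.

Within the data shown here, compound 3 is thus the only compound with an actual number; the other values sit at the limit (the limit of > 400 ug/mL in this assay, at which 2 of the 3 values shown sit). On these data alone, the steps of a number no higher from compound 1 to compound 3 (the limit leaves the size open) and a number no higher from compound 2 to compound 3 (the limit leaves the size open) both end at this number, but their sizes stay open, and the step that the two limits leave unreadable from compound 1 to compound 2 cannot be read at all.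

Compound 4 `Nc1ncnc2c1ncn2CC(O)C(=O)OCCO` differs from compound 3 by hydroxy in place of isopropyl on a saturated chain carbon, two bonds along the chain from an oxygen next to a carbonyl group. Among the measured compounds shown here, no measured step puts a hydroxy group in at this place, so there is nothing directly comparable. The closest is the step of a number no higher from compound 1 to compound 3 (the limit leaves the size open), where a small oxygen-bearing group was exchanged for isopropyl at the same place and the value moved from a limit to a number. Compound 4 undoes such an exchange, so the value is expected to move back toward the limit, and the step of a 1.1-fold higher number from compound 3 to compound 4 (0.05 log units; within the scatter) is estimated in that direction, of a size that may well not exceed the scatter. The estimate for compound 4 is therefore 450 ug/mL, within 200 ug/mL to 1000 ug/mL, with a good chance that only a limit is reported.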

Compound 4, minimum cytotoxic concentration: > 400 ug/mL
Compound 4: only a limit was reported; the forecaster's own chance of this, stated with the estimate: 65%; the middle value lies beyond the limit too.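

Putting hydroxy in place of isopropyl, on a saturated chain carbon, two bonds along the chain from an oxygen next to a carbonyl group, gives in this assay a number no lower from compound 3 to compound 4 (the limit leaves the size open). This shows that the hydroxy ester brings no lower number than the isopentyl ester, although the true gap could be very small. Compound 4 ends at a limit, not a number, and the steps among compounds 1, 2 and 4 cannot be read, so compound 3 remains the only compound with a number: the limit of > 400 ug/mL in this assay, at which 3 of the 4 values shown sit.

The compounds shown leave open how large the step to compound 4 really is. They also leave open whether a longer chain, an amine or a carboxylic acid at this place would give a number inside the range of the test.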